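The compounds below may be only part of what the source reports. "The series", "measured", "known", "first", "only" and "open" are said of these compounds alone.

Measured compounds: compound 1 `CC(C)c1onc(-c2c(Cl)cccc2Cl)c1COc1ccc(N(C)Cc2cccc(C(=O)NCCOP(=O)(O)O)c2)c(C(F)(F)F)n1` gives 36 nM in an assay on isolated protein for agonist activity at Bile acid receptor (Homo sapiens), read by FRET; on this read-out higher numbers stand for an effect only at larger amounts of compound and lower numbers for an effect already at smaller amounts; compound 2 `CC(c1ccc(OCc2c(-c3c(Cl)cccc3Cl)noc2C2CC2)nc1C(F)(F)F)N(C)c1ccc(C(=O)O)cc1` gives 179 nM in this assay.

Compound 2 stands with the higher of the two numbers, and its gap to compound 1 lies beyond the scatter. Compound 3 `CC(Oc1ccc(C(=O)O)cc1)c1ccc(OCc2c(-c3c(Cl)cccc3Cl)noc2C2CC2)nc1C(F)(F)F` differs from compound 2 by 4-carboxyphenoxy in place of (4-carboxyphenyl)(methyl)amino on a saturated chain carbon bound to an aromatic carbon and a saturated chain carbon. Among the measured compounds shown here, no measured pair shows this change, so its size is unknown; a small step, within or just beyond the scatter and toward a higher number, is expected, as a 1.5-fold higher number from compound 2 to compound 3 (0.16 log units; within the scatter). On that basis compound 3 is estimated at 260 nM in this assay, with a range from 80 nM to 850 nM.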

Compound 3, half-maximal effective concentration: 352 nM
Compound 3: the middle estimate sits 1.4-fold (0.13 log units) below what was measured; low and high end bracket the measured number.
By their numbers in this assay, from the lowest: compound 1; then compounds 2 and 3 (each within the scatter of the next).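

With 4-carboxyphenoxy in place of (4-carboxyphenyl)(methyl)amino on a saturated chain carbon bound to an aromatic carbon and a saturated chain carbon, this assay shows a 2.0-fold higher number from compound 2 to compound 3 (0.29 log units; within the scatter). Among the compounds shown here, this single pair therefore gives the first direct reading at this position: the two groups cannot be told apart on this read-out. Nothing available here accounts for this result.

Going by these compounds, it remains open whether a sulfur atom in the same place would also fall within the scatter. On these data alone, what an amide would give in place of the carboxylic acid also remains open.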